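Fluorine pattern on the nitrophenyl arm: compounds 1 to 3

The compounds below may be only part of what the source reports. "The series", "measured", "known", "first", "only" and "open" are said of these compounds alone.

Compound 1 `COC(=O)c1ccc(CN(CCCc2c(N)nc(N)nc2O)c2cc(F)cc(F)c2[N+](=O)[O-])cc1`: > 100000 nM
Compound 2 `COC(=O)c1ccc(CN(CCCc2c(N)nc(N)nc2O)c2cc(F)ccc2[N+](=O)[O-])cc1`: 30000 nM
Compound 3 `COC(=O)c1ccc(CN(CCCc2c(N)nc(N)nc2O)c2cc(F)c(F)cc2[N+](=O)[O-])cc1`: not yet measured

For the measured compounds named here, compound 2 holds the only proper number in a functional assay on CCRF-CEM cells (Homo sapiens) for cytotoxicity, in the presence of a further agent that is not named here; a higher number here means a weaker inhibitor, a lower number a stronger inhibitor; compound 2 gives 30000 nM. For compound 1 the result in this assay is a limit, compound 1 giving > 100000 nM. Going by the values given here, the one measured step, hydrogen in place of fluoro on an aromatic carbon, runs an at least 3.3-fold lower number from compound 1 to compound 2 (0.52 log units; beyond the scatter), its size bounded because of the limit of > 100000 nM in this assay, at which 1 of the 2 values shown sits.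

Compound 3 carries fluoro in place of hydrogen on an aromatic carbon, that is 5-fluoro-2-nitrophenyl becomes 4,5-difluoro-2-nitrophenyl. This reverses the direction of the measured step, though the fluoro enters at another aromatic carbon, so the measured step bears on it only loosely. A weakening, a 2.0-fold higher number from compound 2 to compound 3 (0.30 log units; within the scatter), is therefore expected for compound 3, with a fair chance that only a limit is returned. Compound 3 is estimated at 60000 nM, within 20000 nM to 300000 nM.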

Compound 3, half-maximal inhibitory concentration: 53000 nM
For compound 3 the middle estimate is 1.1-fold (0.05 log units) above the measured one, within the range that was stated.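

In this assay a second fluoro on the carbon ortho to a fluoro group and meta to a nitro group gives a 1.8-fold higher number from compound 2 to compound 3 (0.25 log units; within the scatter), so at this position the added fluoro leaves the number within the scatter. Moving the second fluoro from the 3,5-difluoro-2-nitrophenyl pattern to the 4,5-difluoro-2-nitrophenyl pattern gives an at least 1.8-fold lower number from compound 1 to compound 3 (0.27 log units; that floor lies within the scatter). That figure is only a floor, and it does not set the two difluoro patterns apart: the limit of > 100000 nM in this assay, at which 1 of the 3 values shown sits.

Open, from the compounds shown here alone, is whether a chloro, methoxy or amine group on this same carbon would move the number beyond the scatter. Also open, going by these compounds, is whether a carboxylic acid in place of the ester, on any of these fluorine patterns, would change the reading in this assay.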